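Benzylamine series: aryl swap and acid dissociation

The compounds below may be only part of what the source reports. "The series", "measured", "known", "first", "only" and "open" are said of these compounds alone.

Of the compounds shown here, three have been measured in a physicochemical assay for acid dissociation. Compound 2 `COc1ccc(F)cc1CNCCCNc1ccnc2cc(C3CCCCC3)ccc12` gives 9.47. Compound 1 `COc1cccc(CNCCCNc2ccnc3cc(C4CCCCC4)ccc23)c1O` gives 9.47, and compound 3 `COc1ccc(F)cc1CNCCCNc1ccnc2cc(CCc3ccccc3)ccc12` gives 9.47. The change from compound 2 to compound 1 is 2-hydroxy-3-methoxyphenyl in place of 5-fluoro-2-methoxyphenyl on a saturated chain carbon bound to an amine nitrogen; it made the step of no change at the digits printed from compound 2 to compound 1 (within the scatter). The cores of compound 2 and compound 3 differ by phenethyl in place of cyclohexyl on an aromatic carbon, with the step of no change at the digits printed from compound 2 to compound 3 (within the scatter). Compound 3 thus stands level with compounds 1 and 2 at the digits given.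

Compound 4 `COc1cccc(CNCCCNc2ccnc3cc(CCc4ccccc4)ccc23)c1O` is not yet measured in this assay. It differs from compound 3 by 2-hydroxy-3-methoxyphenyl in place of 5-fluoro-2-methoxyphenyl on a saturated chain carbon bound to an amine nitrogen, the same change as from compound 2 to compound 1, at the same place. In this assay the expected step is no change at the digits printed from compound 3 to compound 4 (within the scatter), set beside the earlier no change at the digits printed from compound 2 to compound 1 (within the scatter), because no change at the digits printed from compound 2 to compound 1 (within the scatter) lay within the scatter and the core difference no change at the digits printed from compound 2 to compound 3 (within the scatter) also lay within it. For compound 4 the estimate is 9.47, with a range from 9.2 to 9.75.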

Compound 4, acid dissociation constant: 9.47
Estimate against measurement, compound 4: no gap at the digits printed; the range from low to high includes it.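

In this assay the change to 2-hydroxy-3-methoxyphenyl from 5-fluoro-2-methoxyphenyl gives no change at the digits printed from compound 3 to compound 4 (within the scatter) on the phenethyl core and no change at the digits printed from compound 2 to compound 1 (within the scatter) on the cyclohexyl core, while phenethyl in place of cyclohexyl gives no change at the digits printed from compound 1 to compound 4 (within the scatter) with the new aryl group in place. The change therefore carries across these two cores with the same null result, and the four compounds form a closed square in which neither change can be read. This agreement does not show that a step of real size would carry from one core to another, and no supporting data bear on why the values coincide.

The compounds shown leave open whether a carboxylic acid or a second amine in place of the 2-hydroxy-3-methoxyphenyl, or a longer chain in place of the phenethyl, would shift the reading beyond the scatter. As far as these compounds go, whether any such step would carry between cores also stays open.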